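From a Benzylsulfanyl Group to an Allylsulfanyl Group

The compounds below may be only part of what the source reports. "The series", "measured", "known", "first", "only" and "open" are said of these compounds alone.

Of the compounds shown here, three that share one core have been tested in a functional assay on MCF7 cells (Homo sapiens) for antiproliferative activity, read by MTT assay, with a stated time of 48 h; a lower number here means a stronger inhibitor, a higher number a weaker inhibitor. Compound 1 `Cc1ccc(-c2nc(NO)c3cc(Cl)ccc3n2)cc1` gives 6.81 ug/mL, compound 2 `Cc1ccc(-c2nc(NC(=O)c3ccccc3)c3cc(Cl)ccc3n2)cc1` gives 16.1 ug/mL, and compound 3 `Cc1ccc(-c2nc(SCc3ccccc3)c3cc(Cl)ccc3n2)cc1` gives 9.66 ug/mL. Compound 3 therefore sits second highest of the three, and its distance to the other two is small: the step of a 1.4-fold higher number from compound 1 to compound 3 (0.15 log units; within the scatter) and the step of a 1.7-fold lower number from compound 2 to compound 3 (0.22 log units; within the scatter) both stay inside the usual scatter, while only a 2.4-fold higher number from compound 1 to compound 2 (0.37 log units; beyond the scatter) goes a little beyond it.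

Compound 4 `C=CCSc1nc(-c2ccc(C)cc2)nc2ccc(Cl)cc12` is the next compound. It differs from compound 3 in one place: vinyl in place of phenyl on a saturated chain carbon bound to a sulfur. Among the measured compounds shown here, none of the measured steps exchanges one sulfur-bound chain for another, so no step speaks directly to this change. The closest hints are the steps into compound 3, which replaced the whole group on that aromatic carbon and still moved little. The expected step of a 1.1-fold higher number from compound 3 to compound 4 (0.06 log units; within the scatter) is therefore small and within the scatter, with no clear direction. Compound 4 is expected to give about 11 ug/mL, within a range from 5 ug/mL to 25 ug/mL.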

Compound 4, half-maximal inhibitory concentration: 8.03 ug/mL
Compound 4: the middle estimate sits 1.4-fold (0.14 log units) above what was measured, and the stated range covers the measured number.
By their numbers in this assay, from the lowest: compounds 1, 4, 3 and 2 (each within the scatter of the next, the first and the last beyond it).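

In this assay, the aromatic ring at the end of the sulfur-bound chain can be replaced without a readable change: swapping phenyl, with 6 heavy atoms, for vinyl, with 2, gives a step within the scatter (a 1.2-fold lower number from compound 3 to compound 4 (0.08 log units; within the scatter)). The allylsulfanyl group also cannot be told apart from hydroxyamino (a 1.2-fold higher number from compound 1 to compound 4 (0.07 log units; within the scatter)) or benzamido (a 2.0-fold lower number from compound 2 to compound 4 (0.30 log units; within the scatter)), although compound 1 and compound 2 differ beyond the scatter. No measurement shown explains why these steps are small.

A simple methyl or a longer chain such as butyl on the sulfur would test whether this tolerance extends beyond benzyl and allyl. A carboxylic acid or an amine at the end of the chain would test whether the position accepts very different groups.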